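A few compounds are considered here, and "the series" means these few. Any claim that something is new, unique, unknown or untested is made for them only; others in the source may bear on it.

Measured compounds:
compound 1, `CO[C@@H]1CC=C2N(c3ccccn3)C(=O)C[C@]2(c2ccccc2)O1`: 6110 nM
compound 2, `CO[C@@H]1CC=C2N(c3c[nH]c4ccccc34)C(=O)C[C@]2(c2ccccc2)O1`: 5200 nM

Both compounds were tested in a functional assay on A549 cells (Homo sapiens) for cytotoxicity, read by sulforhodamine B assay, with a stated time of 48 h; a lower number here means a stronger inhibitor, a higher number a weaker inhibitor. Compound 1 gives 6110 nM and compound 2 gives 5200 nM; the step of a 1.2-fold lower number from compound 1 to compound 2 (0.07 log units; within the scatter) shows that swapping the pyridin-2-yl for a 1H-indol-3-yl on the ring amide nitrogen left the number essentially where it was. Compound 2 therefore stands together with compound 1 inside the usual scatter, and nothing in these two numbers separates the two aryl groups.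

Compound 3, `CO[C@@H]1CC=C2N(c3cc(Cl)cc(Cl)c3)C(=O)C[C@]2(c2ccccc2)O1`, has not been measured. It differs from compound 2 in one place: 3,5-dichlorophenyl in place of 1H-indol-3-yl on an amide-type nitrogen in a ring. Among the measured compounds shown here, the only measured step that bears on this position is a 1.2-fold lower number from compound 1 to compound 2 (0.07 log units; within the scatter), and it was within the scatter. With one substituent exchange at this nitrogen producing no change beyond the noise, a second exchange at the same place is expected to do the same, so no step beyond the scatter is expected in this assay, in either direction.

For compound 3 the expected value in this assay is 5000 nM, between 2000 nM and 14000 nM, which corresponds to an expected step of a 1.0-fold lower number from compound 2 to compound 3 (0.02 log units; within the scatter).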

Compound 3, half-maximal inhibitory concentration: 7530 nM
Compound 3: the middle estimate sits 1.5-fold (0.18 log units) below what was measured; low and high end bracket the measured number.
By their numbers in this assay, from the lowest: compounds 2, 1 and 3 (each within the scatter of the next).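

In this assay, placing 3,5-dichlorophenyl on the amide-type nitrogen in place of 1H-indol-3-yl gives a 1.4-fold higher number from compound 2 to compound 3 (0.16 log units; within the scatter), and placing it there instead of pyridin-2-yl gives a 1.2-fold higher number from compound 1 to compound 3 (0.09 log units; within the scatter). Compound 3 adds chlorine to this position and has no hydrogen-bond donor in the entering group, where 1H-indol-3-yl has one, yet neither difference takes the number beyond the scatter, so all three aryl groups now stand together and the flat reading at this nitrogen no longer rests on a single exchange. No measurement is available that would account for this outcome.

As far as these compounds go, all three groups at this nitrogen are aromatic rings, so it remains open whether a non-aromatic group there, such as a chain carrying an amine or a carboxylic acid, would give a step beyond the scatter. Because only this one place varies, the compounds also leave open how the number responds to changes elsewhere on the shared core, such as replacing the phenyl group with a longer alkyl chain.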